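The compounds below may be only part of what the source reports. "The series", "measured", "known", "first", "only" and "open" are said of these compounds alone.

Measured compounds:

compound 1, `O=C(O)CCc1ccc(OCc2ncc(-c3cccc(Cl)c3)o2)cc1`: 47500 nM
compound 2, `O=C(O)CCc1ccc(OCc2nc(-c3cccc(C(F)(F)F)c3)no2)c(Cl)c1`: 30100 nM
compound 3, `O=C(O)CCc1ccc(OCc2nc(-c3ccc(F)cc3)no2)cc1`: 680 nM

All three values come from a functional assay on CHO cells for agonist activity at Free fatty acid receptor 1 (Homo sapiens), read by FLIPR and calcium flux, in the presence of a further agent that is not named here; on this read-out higher numbers stand for an effect only at larger amounts of compound and lower numbers for an effect already at smaller amounts. Compound 3 stands lowest of the three numbers; compound 2 sits well higher, beyond the scatter, and compound 1 higher still, also beyond the scatter. Within the data shown here, compounds 1 and 2 carry different cores and different substitution from compound 3, so no pair of measured compounds differs in a single place and no single-change step can be read from what has been measured.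

Compound 4, `Cc1ccc(-c2noc(COc3ccc(CCC(=O)O)cc3)n2)cc1`, is the next compound to be run in this assay. It differs from compound 3 by methyl in place of fluoro on an aromatic carbon. Among the measured compounds shown here, nothing among the measured compounds bears on this exchange, so the expectation rests on compound 3 alone. The step from compound 3 to compound 4 is expected to be a 1.1-fold lower number from compound 3 to compound 4 (0.05 log units; within the scatter), a change not beyond the scatter. On that basis compound 4 is estimated at 600 nM, with a range from 200 nM to 2000 nM.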

Compound 4, half-maximal effective concentration: 300 nM
For compound 4 the middle estimate is 2.0-fold (0.30 log units) above the measured one; measured number inside the range.
By their numbers in this assay, from the lowest: compound 4; then compound 3; then compounds 2 and 1 (each within the scatter of the next).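

The readings in this assay give the series its first single-change step: the exchange of 4-fluorophenyl for 4-methylphenyl yields a 2.3-fold lower number from compound 3 to compound 4 (0.36 log units; beyond the scatter) and is modest in size. The position on an aromatic carbon, para to a large group, therefore accepts methyl in place of fluoro without the number rising, so fluoro is not needed there for the lowest values seen so far. Nothing at hand explains the direction of this step, and no cause can be assigned to it.

Going by these compounds, at this position only fluoro and methyl can be compared, so it remains open whether chloro, methoxy, ethyl or a carboxylic acid there would continue the downward step or reverse it. Compound 1 and compound 2 each differ from compound 3 and compound 4 in more than one place, so the steps to them cannot be read, and the separate contributions of the core of compound 1, the trifluoromethyl group and the chloro group of compound 2 remain unresolved.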